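Chloro on the anilino ring: note on compound 4

The source may report more compounds than this note shows. Statements on the series, on what has been measured and on what is new or still open speak of the compounds shown alone.

Compound 1 `COc1cccc(/C=C/C(=O)c2sc(Nc3ccccc3)nc2C)c1` gives only a limit in a functional assay on Bel-7402 cells (Homo sapiens) for cytotoxicity, read by MTT assay (on this read-out lower numbers stand for stronger inhibition and higher numbers for weaker inhibition), namely > 25000 nM. Compound 2 `Cc1nc(Nc2ccccc2)sc1C(=O)/C=C/c1ccc(Cl)cc1` likewise sits at the limit, with > 25000 nM. Compound 3 `Cc1nc(Nc2ccccc2)sc1C(=O)/C=C/c1ccccc1Cl` also returns a limit, > 25000 nM. All three values share (the limit of > 25000 nM in this assay, at which 3 of the 3 values shown sit). The steps a step that the two limits leave unreadable from compound 1 to compound 2, a step that the two limits leave unreadable from compound 1 to compound 3 and a step that the two limits leave unreadable from compound 2 to compound 3 are therefore unreadable, and each of them alters the aryl on the double-bonded chain carbon, not the anilino ring. Compound 4 `COc1cccc(/C=C/C(=O)c2sc(Nc3cccc(Cl)c3)nc2C)c1` differs from compound 1 by chloro in place of hydrogen on an aromatic carbon. No measured step touches this position, so nothing shown gives a size or direction; the expected step that the limit leaves unreadable from compound 1 to compound 4 is small at best. With every value shown at the limit, compound 4 is expected near 30000 nM, within 8000 nM to 100000 nM, most probably again as a limit.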

Compound 4, half-maximal inhibitory concentration: > 25000 nM
Compound 4 was reported as a limit; the forecaster's own chance of this, stated with the estimate: 75%; the middle value is on the limit's open side.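

No new step can be read between compound 1 and compound 4, since both sit at the same limit: the limit of > 25000 nM in this assay, at which 4 of the 4 values shown sit.

The compounds shown leave open what chloro in place of hydrogen does on the anilino ring, and which structural change would give a measurable value in this assay.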